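The source may report more compounds than this note shows. Statements on the series, on what has been measured and on what is new or still open speak of the compounds shown alone.

Values measured in a functional assay on SMMC-7721 cells (Homo sapiens) for cytotoxicity, read by MTT assay, with a stated time of 48 h (on this read-out lower numbers stand for stronger inhibition and higher numbers for weaker inhibition), so far
- compound 1 `CC[N+](CC)(CC)Cc1ccc2oc(-c3ccc([N+](=O)[O-])cc3)cc(=O)c2c1` gives "not determined" (no result reported)
- compound 2 `O=c1cc(-c2ccc([N+](=O)[O-])cc2)oc2c(CN3CCCCC3)cc(Cl)cc12` gives 1090 nM

Among the measured compounds shown here, compound 2 holds the only number, so it has no rank yet, and no step between measured compounds is available as a guide. Compound 3 `O=c1cc(-c2ccc([N+](=O)[O-])cc2)oc2c(Cn3ccnc3)cc(Cl)cc12` keeps the core of compound 2 and differs by 1H-imidazol-1-yl in place of piperidin-1-yl on a saturated chain carbon bound to an aromatic carbon in one place, with 1H-imidazol-1-yl in place of piperidin-1-yl on a saturated chain carbon bound to an aromatic carbon. A modest move towards weaker inhibition is expected in this assay and may stay within the usual scatter, though this rests on a single anchor and is uncertain. The estimated step is a 2.0-fold higher number from compound 2 to compound 3 (0.30 log units; within the scatter) in this read-out. For compound 3 the estimate is 2200 nM with an expected range from 600 nM to 8000 nM in this read-out.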

Compound 3, half-maximal inhibitory concentration: 1200 nM
Compound 3: the middle estimate sits 1.8-fold (0.26 log units) above what was measured; measured number inside the range.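

In this assay, the change from (piperidin-1-yl)methyl to (1H-imidazol-1-yl)methyl gives a 1.1-fold higher number from compound 2 to compound 3 (0.04 log units; within the scatter), the first step available in the series. At this place, on a saturated chain carbon bound to an aromatic carbon, a six-membered non-aromatic ring and a five-membered aromatic ring with 2 hetero atoms therefore cannot be told apart by this read-out. No measured property is available to explain this match.

Two groups that read alike do not show whether this place matters for the read-out at all; a morpholin-4-yl group, an open-chain diethylamino group or a carboxylic acid on the same chain carbon would bear on that. On these data alone, it also stays open whether the same match holds on a core other than the one shared by these two compounds.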